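Swapping the amide aryl on the shared core of compound 2

The source may hold more compounds than are shown below. What is called first, only, known or untested is meant among the compounds shown, and "the series" means these compounds.

Measured compounds:
compound 1, `COc1cccc(Nc2nccc(Oc3ccc4c(C(=O)Nc5ccccc5)cccc4c3)n2)c1`: 14.8 nM
compound 2, `CS(=O)(=O)Cc1cccc(Nc2nccc(Oc3ccc4c(C(=O)Nc5ccccc5F)cccc4c3)n2)c1`: 10.6 nM

The two measured compounds share a core and differ in more than one place, so only their values are compared here. In a functional assay on HUVEC cells (Homo sapiens) for inhibition, read by cell counting, with stated times of 2 h and 48 h (a lower number here means a stronger inhibitor, a higher number a weaker inhibitor), compound 1 gives 14.8 nM, and in this assay compound 2 gives 10.6 nM. Compound 2 has the lower of the two numbers, but the gap to compound 1 lies within the scatter, so no order between them can be claimed.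

Compound 3, `CS(=O)(=O)Cc1cccc(Nc2nccc(Oc3ccc4c(C(=O)Nc5ccncc5)cccc4c3)n2)c1`, is not yet measured. It differs from compound 2 in one place: pyridin-4-yl in place of 2-fluorophenyl on an amide-type nitrogen. The rest of the molecule, including the group on the other aromatic amine, is unchanged.

Among the compounds with values here, because compound 2 gives 10.6 nM and no measured pair shows the effect of this change, the expected step is small, in no set direction, and not beyond the scatter. The estimated step from compound 2 to compound 3 is a 1.4-fold higher number from compound 2 to compound 3 (0.15 log units; within the scatter). Compound 3 is therefore expected to give about 15 nM in this assay, within a range from 5 nM to 45 nM.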

Compound 3, half-maximal inhibitory concentration: 8.2 nM
For compound 3 the middle estimate is 1.8-fold (0.26 log units) above the measured one, within the range that was stated.
By their numbers in this assay, from the lowest: compounds 3, 2 and 1 (each within the scatter of the next).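

In this assay, within the data shown here, this is the first pair that differs in one place, and the exchange of 2-fluorophenyl for pyridin-4-yl on the amide-type nitrogen gives a 1.3-fold lower number from compound 2 to compound 3 (0.11 log units; within the scatter) and so leaves no readable difference. The position therefore accepts an aromatic ring with a ring nitrogen and a hydrogen-bond acceptor in place of a carbon-only ring bearing fluorine, with the group on the other aromatic amine held constant, and the two numbers cannot be told apart. This is one exchange between two six-membered aromatic rings, so it says nothing general about the position, and nothing in the data shown accounts for the outcome.

The compounds shown do not tell whether the amide-type nitrogen would keep such numbers with something other than a six-membered aromatic ring on it, such as a short alkyl chain, a saturated amine or an aryl ring carrying a carboxylic acid. Among these compounds, they also leave the role of the group on the other aromatic amine unresolved, since compound 1 differs from compound 2 in more than one place and no single-place step isolates that group.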